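This account rests on a few compounds, and the source may have more. Where it says the series, first, only, none or still open, it means among the compounds named here.

Of the compounds shown here, three sharing one core have been measured in an ADME assay on microsomes from liver (Homo sapiens) for metabolic stability, with a stated time of 10 min, tested at 0.5 uM; on this read-out lower numbers stand for a less stable compound and higher numbers for a more stable compound. Compound 1 (`C[C@@H](NC(=O)Nc1ccc(Cl)cc1)[C@H]1CC[C@@H](c2ccnc3ccc(F)cc32)CC1`) gives 52%, compound 2 (`C[C@@H](NC(=O)c1cccc(Cl)c1)[C@H]1CC[C@@H](c2ccnc3ccc(F)cc32)CC1`) gives 39%, and compound 3 (`C[C@@H](NC(=O)c1ccccc1Cl)[C@H]1CC[C@@H](c2ccnc3ccc(F)cc32)CC1`) gives 21%, the lowest of the three. Compound 4 (`C[C@@H](NC(=O)C12CCC(Cl)(CC1)CC2)[C@H]1CC[C@@H](c2ccnc3ccc(F)cc32)CC1`) departs from compound 3 on the carbonyl carbon: a group of 9 heavy atoms (8 carbon, 1 chlorine; 2 six-membered non-aromatic rings of carbon only) in place of a group of 7 heavy atoms (6 carbon, 1 chlorine; one six-membered aromatic ring of carbon only), on a carbonyl carbon. Going by the values given here, no measured step replaces the aromatic ring, so the evidence is indirect. The nearest steps are changes at the same place, and each lies beyond the scatter: a number 13 percentage points lower from compound 1 to compound 2 (beyond the scatter), a number 31 percentage points lower from compound 1 to compound 3 (beyond the scatter) and a number 18 percentage points lower from compound 2 to compound 3 (beyond the scatter). These show that the read-out in this assay can move by modest to large amounts with the group on this carbon, but they give no direction for a group without an aromatic ring. With compound 3 at 21%, no step beyond the scatter is expected, though the uncertainty is wide. The expected outcome is a number 6 percentage points higher from compound 3 to compound 4 (within the scatter). For compound 4 the estimated value is 27%, with an expected range of 10% to 50%.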

Compound 4, percent of the compound remaining: 9%
Estimate against measurement, compound 4: 18 percentage points above; the measured number lies below the stated range.
By their numbers in this assay, from the lowest: compound 4; then compound 3; then compound 2; then compound 1.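

In this assay, going by these compounds alone, the step away from the aromatic ring gives the first direction for a group without one on this carbonyl carbon: a number 12 percentage points lower from compound 3 to compound 4 (beyond the scatter) and a number 30 percentage points lower from compound 2 to compound 4 (beyond the scatter) and also a number 43 percentage points lower from compound 1 to compound 4 (beyond the scatter). Compound 4 is therefore the least stable of the four, so a chlorine-bearing group of two six-membered non-aromatic rings of carbon only does not lift the read-out above the chlorophenyl amides or the (4-chlorophenyl)amino compound. Nothing available explains why the number falls with this group.

The compounds shown leave open whether the chlorine of the new group plays any part, since no version carrying a hydroxyl group, an amine or a carboxylic acid in its place appears. They also leave open how a plain cyclohexyl group on the same carbonyl carbon would compare.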